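The source may hold more compounds than are shown below. What is called first, only, known or untested is meant among the compounds shown, and "the series" means these compounds.

The study compares four carbamates that share a core and differ in the halogen pattern of the aryl carbamate and in the chain on the core. Compound 1 `CC(C)=CCC1Cc2c(OC(=O)Nc3ccc(F)cc3)cc(=O)n(CCCO)c2CC1(C)C` carries a 4-fluorophenyl group, and compound 2 `CC(C)=CCC1Cc2c(OC(=O)Nc3ccc(Cl)cc3)cc(=O)n(CCCO)c2CC1(C)C` is its 4-chlorophenyl counterpart. In a functional assay on PANC-1 cells (Homo sapiens) for inhibition, read by MTT assay, with a stated time of 24 h, tested at 10 uM (a lower number here means less inhibition, a higher number more inhibition at the concentration tested (going by the name of the read-out)), compound 1 gives 0%. In this assay compound 2 gives 0%. The change between them is chloro in place of fluoro on an aromatic carbon, and it made no change at the digits printed from compound 1 to compound 2 (within the scatter).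

Compound 3 `CC(C)=CCC/C(C)=C/CC1Cc2c(OC(=O)Nc3ccc(F)c(F)c3)cc(=O)n(CCCO)c2CC1(C)C` rests on a different core; the difference between the two cores is not broken down here. In this assay compound 3 gives 4.8%, a number within the scatter of the values of compound 1 and compound 2.

Compound 4 `CC(C)=CCC/C(C)=C/CC1Cc2c(OC(=O)Nc3ccc(F)c(Cl)c3)cc(=O)n(CCCO)c2CC1(C)C` has not yet been measured. It differs from compound 3 by chloro in place of fluoro on an aromatic carbon. This is the same kind of change as that from compound 1 to compound 2, though the place differs: in compound 1 the fluoro stands para to a large group, while in compound 3 it stands ortho to a fluoro group and meta to a large group.

Because the earlier step of no change at the digits printed from compound 1 to compound 2 (within the scatter) lay within the scatter, and because compound 3 gives 4.8%, compound 4 is expected to move little, with an estimated step of a number 0.2 percentage points higher from compound 3 to compound 4 (within the scatter). Compound 4 is therefore estimated at 5%, expected to fall between 0% and 15%.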

Compound 4, a percentage reported as inhibition, at one concentration (the size of the read-out at that concentration, not a potency): 0%
The estimate for compound 4 lay 5 percentage points above the measured number, and the stated range covers the measured number.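

In this assay, chloro in place of fluoro gives a number 4.8 percentage points lower from compound 3 to compound 4 (within the scatter), and this step agrees with the earlier one on the other core: the same change on two cores in this assay, no change at the digits printed (within the scatter) from compound 1 to compound 2 and a number 4.8 percentage points lower (within the scatter) from compound 3 to compound 4, 4.8 percentage points apart, within the scatter of two such steps. Within this small set, the change therefore carries from one core to the other without a step that can be told from the scatter, even though on compound 3 the fluoro being replaced stands ortho to a fluoro group and meta to a large group. Going by these compounds alone, this does not show that the change is without effect in general, since all four readings lie within the scatter of one another and so give no compound with clear inhibition against which a step could show itself.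

The compounds shown leave open whether the same change would stay as small on a compound with clear inhibition, and whether an aryl carbamate bearing a methoxy group, a nitrile or an amine instead of a halogen would read any differently. They also leave open what a carboxylic acid or a longer chain in place of the hydroxyl-bearing chain on the ring nitrogen would do in this assay.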